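The source may report more compounds than this note shows. Statements on the series, on what has been measured and on what is new or still open speak of the compounds shown alone.

Measured compounds:
Compound 1 `COc1cc(/C=N/NC(=O)Nc2cccc3ccccc23)ccc1O` — 300 mg/kg
Compound 2 `COc1ccc(/C=N/NC(=O)Nc2cccc3ccccc23)cc1OC` — 100 mg/kg
Compound 3 `O=C(N/N=C/c1ccc(Br)cc1)Nc1cccc2ccccc12` — 300 mg/kg

In a functional assay on the whole organism (strain Swiss albino) with Mus musculus as the target, in the maximal electroshock model, with a stated time of 0.5 h (a lower number here means that less compound is needed, a higher number that more compound is needed for the effect), compound 3 gives 300 mg/kg, level with compound 1 at the digits shown, and the two together stand as the highest numbers of the three; compound 2, the furthest from it, lies a step lower by a 3.0-fold lower number from compound 1 to compound 2 (0.48 log units; beyond the scatter), the only step between measured compounds that differ in one place. That step concerns methyl in place of hydrogen on an oxygen on an aromatic ring and so does not bear on the change now in question.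

Compound 4 `O=C(N/N=C/c1ccc([N+](=O)[O-])cc1)Nc1cccc2ccccc12` differs from compound 3 in one place: nitro in place of bromo on an aromatic carbon. Within the data shown here, no measured pair shows an exchange of one group for another on that aromatic carbon, so the data give no direction for this change in this assay. Compound 4 is therefore expected to stay near compound 3, with a step of about no change at the digits printed from compound 3 to compound 4 (within the scatter), not beyond the scatter. The estimate for compound 4 is 300 mg/kg, within a range from 100 mg/kg to 600 mg/kg.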

Compound 4, minimum effective dose: 300 mg/kg
The estimate for compound 4 equals the measured number at the digits printed, and the stated range covers the measured number.
By their numbers in this assay, from the lowest: compound 2; then compounds 1, 3 and 4 (each within the scatter of the next).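

Nitro in place of bromo on an aromatic carbon, para to a large group, gives no change at the digits printed from compound 3 to compound 4 (within the scatter), the only reading so far of one group exchanged for another at this position. A single bromine gives way to a group of three heavy atoms with two hydrogen-bond acceptors, yet the number in this assay stays where it was, so this position tolerates this particular exchange without a change beyond the scatter. Nothing measured here accounts for the two groups reading alike.

Going by these compounds, what remains open is whether that holds for other kinds of group at this position, such as an amine or a carboxylic acid. One pair also cannot say whether the same exchange would read alike on a different substitution pattern of that ring.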